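The source may hold more compounds than are shown below. What is called first, only, known or untested is meant among the compounds shown, and "the series" means these compounds.

Working notes on the series. In an assay on membranes from CHO cells for displacement of a labelled ligand from adenosine receptor A1 (Homo sapiens), read by scintillation counting, with a stated time of 60 min, tested at 1 uM (a lower number here means less inhibition, a higher number more inhibition at the concentration tested (going by the name of the read-out)), compound 1 `CCCOC(=O)C1=C(C)N(C)C(=O)NC1c1ccco1` gives 3% and compound 2 `CC1=C(C(=O)OCC(C)C)C(c2ccco2)NC(=O)N1C` gives 13%. For the measured compounds named here, compound 2 stands highest of the two numbers, with compound 1 nearest, though the one measured step, a number 10 percentage points higher from compound 1 to compound 2 (within the scatter), lies within the scatter. Compound 3 `CC1=C(C(=O)OCC(C)C)C(c2ccsc2)NC(=O)N1C` carries thiophen-3-yl in place of furan-2-yl on a saturated ring carbon. Going by the values given here, no measured step concerns the group on the saturated ring carbon, so the change has no precedent here; the only step available, a number 10 percentage points higher from compound 1 to compound 2 (within the scatter), sits elsewhere and is within the scatter. The expected step is therefore a number 2 percentage points higher from compound 2 to compound 3 (within the scatter), none beyond the scatter. Compound 3 is estimated at 15%, in a range from 2% to 35%.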

Compound 3, a percentage reported as inhibition, at one concentration (the size of the read-out at that concentration, not a potency): 8%
Compound 3: the middle estimate sits 7 percentage points above what was measured; low and high end bracket the measured number.
By their numbers in this assay, from the lowest: compounds 1, 3 and 2 (each within the scatter of the next).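

Thiophen-3-yl in place of furan-2-yl on the saturated ring carbon gives the first reading at this position: in this assay the change gives a number 5 percentage points lower from compound 2 to compound 3 (within the scatter). At this one concentration, the two five-membered aromatic rings are therefore not separated from each other. No supporting measurement bears on this result. As far as these compounds go, whether phenyl or a ring carrying an amine on this same carbon would give a number beyond the scatter remains open. So does whether the same exchange would read alike with the propoxycarbonyl group of compound 1.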